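The source may report more compounds than this note shows. Statements on the series, on what has been measured and on what is new or still open speak of the compounds shown alone.

Compound 1 `COc1nc(C2CCOCC2)ccc1[C@@H](c1ccccc1)[C@@](O)(CCN(C)C)c1cccc2ccccc12` gives > 50 ug/mL in a toxicity assay on Vero cells (Chlorocebus sabaeus) for cytotoxicity; a higher number here means that more compound is tolerated, a lower number that less compound is tolerated; this is a limit of the assay, not a number.
Compound 2 `COc1ncc(-c2ccccc2)cc1[C@@H](c1ccccc1)[C@@](O)(CCN(C)C)c1ccccc1` gives > 50 ug/mL in this assay; again a limit only.
Compound 3 `COc1nc(-c2ccccc2F)ccc1[C@@H](c1ccccc1)[C@@](O)(CCN(C)C)c1cccc2ccccc12` gives > 50 ug/mL in this assay; again a limit only.

Compound 3 therefore stands at the limit, and so does every other value shown, (the limit of > 50 ug/mL in this assay, at which 3 of the 3 values shown sit). Going by the values given here, the one measured step that touches compound 3, a step that the two limits leave unreadable from compound 1 to compound 3, runs from one limit to another and has no readable size; nothing yet separates any two compounds in this assay.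

Compound 4 `COc1nc(-c2ccc(OC(F)(F)F)cc2)ccc1[C@@H](c1ccccc1)[C@@](O)(CCN(C)C)c1cccc2ccccc12` differs from compound 3 by 4-(trifluoromethoxy)phenyl in place of 2-fluorophenyl on an aromatic carbon. Among the compounds with values here, no measured step bears on this change with a readable size; the only step at the same place, a step that the two limits leave unreadable from compound 1 to compound 3, is unreadable. With all values shown sitting at the limit, (the limit of > 50 ug/mL in this assay, at which 3 of the 3 values shown sit), no step beyond the scatter is expected in this assay for this change. Compound 4 is expected to give 50 ug/mL in this assay, within 25 ug/mL to 100 ug/mL. The expected step of a number no higher from compound 3 to compound 4 (the limit leaves the size open) is thus estimated to stay within the scatter, most likely reported again as a limit.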

Compound 4, half-maximal cytotoxic concentration: > 50 ug/mL
Compound 4: only a limit was reported; the forecaster's own chance of this, stated with the estimate: 80%; the middle value sits exactly at the limit.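

Going by these compounds alone, compound 4 gives > 50 ug/mL in this assay, a limit only, and no step to it from compound 3 or compound 1 can be read. The compounds shown leave open where any cytotoxic concentration lies, and whether these changes alter it, with every value at one limit: the limit of > 50 ug/mL in this assay, at which 4 of the 4 values shown sit.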